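Notes on compound 2 and compound 3

The source may hold more compounds than are shown below. What is called first, only, known or untested is meant among the compounds shown, and "the series" means these compounds.

Measured in a functional assay on U-373MG ATCC cells (Homo sapiens) for inhibition, read by MTT assay, with a stated time of 72 h (on this read-out higher numbers stand for weaker inhibition and lower numbers for stronger inhibition), so far:
- compound 1 `CC1(C)CC(NC(=S)Nc2cccc([N+](=O)[O-])c2)c2cc(Br)ccc2O1` gives 4000 nM as its value
- compound 2 `CC1(C)CC(NC(=S)Nc2ccccc2)c2cc(Cl)ccc2O1` gives 46000 nM as its value

Compound 2 holds the higher of the two numbers, and its gap to compound 1 lies beyond the scatter. These two compounds differ in more than one place, so no single change can be read from that gap. Among the compounds with values here, compound 3 `CC1(C)CC(NC(=S)Nc2cccc([N+](=O)[O-])c2)c2cc(Cl)ccc2O1` keeps the core of compound 2 and has nitro in place of hydrogen on an aromatic carbon as its only change. Within the data shown here, no measured pair isolates this change. Compound 1, which also carries the nitro, gives 4000 nM in this assay and so points to an expected fall in the number, beyond the scatter. The expected step is a 7.7-fold lower number from compound 2 to compound 3 (0.88 log units; beyond the scatter) on this estimate. Compound 3 is estimated at 6000 nM with a range from 2500 nM to 20000 nM in this assay.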

Compound 3, half-maximal inhibitory concentration: 3000 nM
Estimate against measurement, compound 3: 2.0-fold (0.30 log units) above; measured number inside the range.
By their numbers in this assay, from the lowest: compounds 3 and 1 (each within the scatter of the next); then compound 2.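

In this assay, within the data shown here, nitro in place of hydrogen on an aromatic carbon, meta to a large group, gives a 15-fold lower number from compound 2 to compound 3 (1.19 log units; beyond the scatter); this is the first reading of this position with only one change, and the step is large. Chloro in place of bromo on an aromatic carbon gives a 1.3-fold lower number from compound 1 to compound 3 (0.12 log units; within the scatter), so with the nitro in place, the two halogens are not separated in this assay, and the earlier gap between compound 1 and compound 2 matches the nitro step. Nothing at hand explains the size of the nitro step.

The compounds shown carry only hydrogen or nitro at this carbon, so how a nitrile, an amine or a carboxylic acid there would compare stays open. Also open is whether chloro and bromo would still match with hydrogen at that carbon, since only the chloro is shown in that setting.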